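Methylphenyl in Place of Cyanopyridinyl on the Pyrazole

The source may hold more compounds than are shown below. What is called first, only, known or untested is meant among the compounds shown, and "the series" means these compounds.

Three compounds share a core and differ only in the aryl group on an aromatic carbon of the pyrazole. In a functional assay on BJAB cells (Homo sapiens) for antiproliferative activity, with a stated time of 4 days (on this read-out lower numbers stand for an effect already at smaller amounts and higher numbers for an effect only at larger amounts of compound), compound 1 `COc1ccc(C)cc1-c1c(C)nn(-c2nc(-c3ccc(Cl)c(Cl)c3)c(SC(C)C)s2)c1C(=O)O` gives 9500 nM, compound 2 `Cc1cc(C#N)cc(-c2c(C)nn(-c3nc(-c4ccc(Cl)c(Cl)c4)c(SC(C)C)s3)c2C(=O)O)c1` gives 4800 nM, and compound 3 `Cc1nn(-c2nc(-c3ccc(Cl)c(Cl)c3)c(SC(C)C)s2)c(C(=O)O)c1-c1cncc(C#N)c1` gives 20000 nM. Compound 3 stands highest of the three: its nearest neighbour is compound 1, at a 2.1-fold higher number from compound 1 to compound 3 (0.32 log units; beyond the scatter), and its furthest is compound 2, at a 4.2-fold higher number from compound 2 to compound 3 (0.62 log units; beyond the scatter); between the other two a 2.0-fold lower number from compound 1 to compound 2 (0.30 log units; within the scatter) was seen.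

Compound 4 `Cc1cccc(-c2c(C)nn(-c3nc(-c4ccc(Cl)c(Cl)c4)c(SC(C)C)s3)c2C(=O)O)c1` arises from compound 3 by 3-methylphenyl in place of 5-cyanopyridin-3-yl on an aromatic carbon. Going by the values given here, the step that bears most on this change is the one between compound 2 and compound 3, where the 3-cyano-5-methylphenyl analogue gave the lower number, and the two six-membered rings of carbon only both gave lower numbers than the 5-cyanopyridin-3-yl ring. A modest step downward beyond the scatter is therefore expected for compound 4 in this assay, about a 2.9-fold lower number from compound 3 to compound 4 (0.46 log units; beyond the scatter), with an estimated value of 7000 nM in the range 2500 nM to 20000 nM.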

Compound 4, half-maximal effective concentration: 17000 nM
Beside the measured number, compound 4's estimate is 2.4-fold (0.39 log units) below it; measured number inside the range.
By their numbers in this assay, from the lowest: compounds 2, 1, 4 and 3 (each within the scatter of the next, the first and the last beyond it).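

In this assay the ring change gives a 1.2-fold lower number from compound 3 to compound 4 (0.07 log units; within the scatter) and so does not separate the 5-cyanopyridin-3-yl and 3-methylphenyl rings, although they differ in ring nitrogen and cyano group. On the carbon-only ring, hydrogen in place of cyano gives a 3.5-fold higher number from compound 2 to compound 4 (0.55 log units; beyond the scatter) while hydrogen in place of methoxy gives a 1.8-fold higher number from compound 1 to compound 4 (0.25 log units; within the scatter) and only the first of these steps lies beyond the scatter. No measurement offered here accounts for either result.

The compounds leave open how a plain pyridin-3-yl ring would compare, which would separate the ring nitrogen from the cyano group. They also leave open how an amine, a carboxylic acid or a longer chain on the aryl ring would read in this assay and whether any such group would extend the range seen so far.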